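This account rests on a few compounds, and the source may have more. Where it says the series, first, only, none or still open, it means among the compounds named here.

The measured compounds in this series are:

Compound 1 `S=C(NCc1ccccc1)Nc1ccc2ncnc(Nc3ccccc3Br)c2c1` gives > 30000 nM
Compound 2 `Cc1cccc(Nc2ncnc3ccc(NC(=S)NCc4ccccc4)cc23)c1C` gives 28700 nM
Compound 3 `CCc1cccc(Nc2ncnc3ccc(NC(=S)NCc4ccccc4)cc23)c1` gives 10500 nM

In a functional assay on MDA-MB-231 cells (Homo sapiens) for inhibition, read by MTT assay, with a stated time of 48 h (on this read-out higher numbers stand for weaker inhibition of growth and lower numbers for stronger inhibition of growth), compound 1 stands at > 30000 nM, which is a limit of the assay and not a number (the limit of > 30000 nM in this assay, at which 1 of the 3 values shown sits). Compound 2 gives 28700 nM in this assay. Compound 3 gives 10500 nM in this assay.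

The unmeasured compound 4 `CC(C)(C)c1ccc(Nc2ncnc3ccc(NC(=S)NCc4ccccc4)cc23)cc1` shares the core of compound 1 and differs from it by 4-(tert-butyl)phenyl in place of 2-bromophenyl on a nitrogen on an aromatic ring. The three measured steps all replace the 2-bromophenyl or vary its successor: an at least 1.0-fold lower number from compound 1 to compound 2 (0.01 log units; that floor lies within the scatter), an at least 2.8-fold lower number from compound 1 to compound 3 (0.45 log units; beyond the scatter) and a 2.7-fold lower number from compound 2 to compound 3 (0.44 log units; beyond the scatter). Both replacements of the 2-bromophenyl led away from the limit, and the 3-ethylphenyl did so by a modest margin. The 4-(tert-butyl)phenyl is another replacement of that group, so a number rather than a limit is expected for compound 4, though it lies outside the variations measured so far.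

Compound 4 is therefore expected to give 15000 nM in this assay, within a range from 4000 nM to 60000 nM. This estimate means a step of an at least 2.0-fold lower number from compound 1 to compound 4 (0.30 log units; that floor lies within the scatter), expected to be of modest size at most.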

Compound 4, concentration for 50% growth inhibition: 8700 nM
Beside the measured number, compound 4's estimate is 1.7-fold (0.24 log units) above it, within the range that was stated.
By their numbers in this assay, from the lowest: compounds 4 and 3 (each within the scatter of the next); then compound 2. At a limit, above all of these: compound 1.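

In this assay, the 4-(tert-butyl)phenyl is a third replacement of the 2-bromophenyl on a nitrogen on an aromatic ring that gives a number, with an at least 3.4-fold lower number from compound 1 to compound 4 (0.53 log units; beyond the scatter), and it does so with 10 heavy atoms in place of 7. Among the replacements, a 1.2-fold lower number from compound 3 to compound 4 (0.08 log units; within the scatter) means that the 4-(tert-butyl)phenyl and the 3-ethylphenyl cannot be told apart here, whereas a 3.3-fold lower number from compound 2 to compound 4 (0.52 log units; beyond the scatter) sets the 2,3-dimethylphenyl of compound 2 apart from the 4-(tert-butyl)phenyl, as it already stood apart from the 3-ethylphenyl. Compound 1 remains a limit and not a number, so the step from it gives only a floor: the limit of > 30000 nM in this assay, at which 1 of the 4 values shown sits.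

The groups shown at this place are all phenyl rings bearing only carbon substituents or bromine, so it remains open how a methoxy, an amine or a carboxylic acid on that ring would read in this assay. On these data alone, it also remains open whether a longer chain than the tert-butyl would move the number any further from those of compound 3 and compound 4.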